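The compounds below may be only part of what the source reports. "The series", "measured", "known", "first", "only" and "open" are said of these compounds alone.

Measured compounds:
- compound 1 `Cc1ccc(-c2nnc(COc3cnn(C(C)(C)C)c(=O)c3Cl)o2)cc1` gives 19.9 ug/mL in a functional assay on the whole organism for inhibition, with Mythimna separata as the target, with a stated time of 5 days; a higher number here means that more compound is needed for the effect, a lower number that less compound is needed
- compound 2 `CC(C)(C)n1ncc(OCc2nnc(-c3ccc(Cl)cc3)o2)c(Cl)c1=O` gives 1.9 ug/mL in this assay
- compound 3 `CC(C)(C)n1ncc(OCc2nnc(-c3ccccc3)o2)c(Cl)c1=O` gives 12.2 ug/mL in this assay

Compound 3 stands second highest of the three numbers in this assay: its nearest neighbour is compound 1, with a 1.6-fold lower number from compound 1 to compound 3 (0.21 log units; within the scatter), while compound 2 lies furthest away, with a 6.4-fold higher number from compound 2 to compound 3 (0.81 log units; beyond the scatter). Compound 4 `CC(C)(C)n1ncc(OCc2nnc(-c3ccco3)o2)c(Cl)c1=O` is the unmeasured member; its change from compound 3 is furan-2-yl in place of phenyl on an aromatic carbon. Going by the values given here, no measured step exchanges the ring itself: the two steps that involve compound 3 only vary a substituent on that ring, and one of them, a 1.6-fold lower number from compound 1 to compound 3 (0.21 log units; within the scatter), lies within the scatter, while the other, a 6.4-fold higher number from compound 2 to compound 3 (0.81 log units; beyond the scatter), is modest. Among the compounds with values here, the ring swap therefore has no direct precedent here, and the expectation in this assay is a step of no clear direction, a 1.2-fold higher number from compound 3 to compound 4 (0.09 log units; within the scatter), with a wide range. Compound 4 is estimated at 15 ug/mL in this assay, between 5 ug/mL and 45 ug/mL.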

Compound 4, half-maximal effective concentration: > 300 ug/mL
Compound 4: no number, only a limit; the forecaster's own chance of this, stated with the estimate: 10%; at least 20-fold (1.30 log units) between middle value and limit.
By their numbers in this assay, from the lowest: compound 2; then compounds 3 and 1 (each within the scatter of the next). At a limit, above all of these: compound 4.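

Going by these compounds alone, exchanging the six-membered aromatic ring itself, not just a substituent on it, moves the number further in this assay than any substituent step among the earlier compounds: an at least 24-fold higher number from compound 3 to compound 4 (1.39 log units; beyond the scatter). The same holds against the two substituted partners, with an at least 150-fold higher number from compound 2 to compound 4 (2.19 log units; beyond the scatter) and an at least 15-fold higher number from compound 1 to compound 4 (1.17 log units; beyond the scatter), so furan-2-yl stands behind phenyl, 4-chlorophenyl and 4-methylphenyl alike at this position. For compound 4 the reading is a limit and not a number: the limit of > 300 ug/mL in this assay, at which 1 of the 4 values shown sits.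

Furan-2-yl is the only five-membered ring shown here, so the compounds leave ring size and the ring oxygen unseparated. A thiophen-2-yl group, which keeps the five-membered ring without the oxygen, and a pyridin-2-yl group, which keeps the six-membered ring with a hetero atom, would tell the two apart.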